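Phenyl in Place of 2,5-Dimethoxyphenyl in Compound 1

This account rests on a few compounds, and the source may have more. Where it says the series, first, only, none or still open, it means among the compounds named here.

Of the compounds shown here, three have been measured so far, and all of them give only weak inhibition. In an ADME assay on DU-145 cells (Homo sapiens) for cytotoxicity, read by MTT assay, with a stated time of 72 h (on this read-out higher numbers stand for weaker inhibition and lower numbers for stronger inhibition), compound 1 (`COc1ccc(OC)c(C2=C(c3cc(OC)c(OC)c(OC)c3)C(=O)CC2O[SiH2]C(C)(C)C)c1`) gives 100 ug/mL and holds the higher of the two actual numbers. Compound 3 (`COc1ccc(C2=C(c3cc(OC)c(OC)c(OC)c3)C(=O)C(O)C2)cc1Cl`) gives 40 ug/mL in the same test, and its gap to compound 1 lies beyond the usual scatter. Compound 2 (`COc1cc(C2=C(c3cc(C)c(OC)c(C)c3)C(OC(C)=O)CC2=O)cc(OC)c1OC`) gives > 100 ug/mL as its result, and that result is a limit of the assay, not a number.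

The next compound to be tested is compound 4 (`COc1cc(C2=C(c3ccccc3)C(O[SiH2]C(C)(C)C)CC2=O)cc(OC)c1OC`), which carries phenyl in place of 2,5-dimethoxyphenyl on a double-bonded ring carbon. Within the data shown here, no pair of measured compounds differs in one place only, so the data hold no direct precedent for this change. The expectation therefore rests on compound 1 at 100 ug/mL and on compound 3 at 40 ug/mL as the nearest number. In this assay no step beyond the scatter is expected, and the estimated change is a 1.4-fold lower number from compound 1 to compound 4 (0.15 log units; within the scatter) in this account. In this assay compound 4 is expected at 70 ug/mL with a range from 30 ug/mL to 160 ug/mL in this estimate.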

Compound 4, half-maximal inhibitory concentration: > 100 ug/mL
Compound 4 gave a limit, no number; the forecaster's own chance of this, stated with the estimate: 35%; at least 1.4-fold (0.15 log units) between middle value and limit.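

Among these compounds, this is the first change on a double-bonded ring carbon of the shared core that can be read directly in this assay, and it gives a number no lower from compound 1 to compound 4 (the limit leaves the size open). Phenyl in place of 2,5-dimethoxyphenyl therefore brings no stronger inhibition at this position, which the earlier compounds, with no pair differing in one place, could not show. The size of the step stays unreadable, and this limit is not an isolated result in the series: the limit of > 100 ug/mL in this assay, at which 2 of the 4 values shown sit.

The compounds shown leave open whether any other group at this position could give a lower number than compound 1, for example a phenyl ring carrying an amine or a carboxylic acid. They also leave open what lies behind the lower number of compound 3, which differs from compound 1 in more than one place and so gives no direct reading of any single change.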